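The source may report more compounds than this note shows. Statements on the series, on what has been measured and on what is new or still open speak of the compounds shown alone.

Measured so far:
compound 1, `COc1cc(-c2cc(/C=C/C(=O)c3ccc(N)cc3)[nH]n2)cc(OC)c1OC`: -93%
compound 2, `COc1ccc(-c2cc(/C=C/C(=O)c3ccc(OC)c(OC)c3)[nH]n2)cc1`: -100%

Of the compounds shown here, two sharing the same core have been measured in a functional assay on UO-31 cells (Homo sapiens) for cytotoxicity, read by sulforhodamine B assay, with a stated time of 48 h, tested at 100 uM; a lower number here means a stronger effect, a higher number a weaker effect of the compound at the concentration tested. Compound 1 gives -93%, and compound 2 gives -100%. The gap separating compound 1 from compound 2 lies within the scatter of the assay, so the two numbers cannot be told apart, and both signal an essentially complete effect at the concentration tested.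

Compound 3, `COc1cc(-c2cc(/C=C/C(=O)c3ccc(Cl)c(Cl)c3)[nH]n2)cc(OC)c1OC`, has not yet been measured in this assay. It keeps the core of compound 1 and differs from it at one spot: 3,4-dichlorophenyl in place of 4-aminophenyl on a carbonyl carbon.

Within the data shown here, no step between measured compounds is available to guide the expectation, so it rests on the two numbers alone. Both measured compounds sit near the floor of what the read-out can show, and the change does not touch the shared core. A step from compound 1 to compound 3 of a number 8 percentage points higher from compound 1 to compound 3 (within the scatter) is therefore expected, that is, no change beyond the scatter or at most a slight weakening. For compound 3 a value of -85% is estimated, with a likely range from -100% to -40%.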

Compound 3, a percentage reported as activity, at one concentration (the size of the read-out at that concentration, not a potency): 18%
Compound 3: the middle estimate sits 103 percentage points below what was measured; measured number above the stated range.
By their numbers in this assay, from the lowest: compounds 2 and 1 (each within the scatter of the next); then compound 3.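

In this assay the group on the carbonyl carbon proves not to be a silent part of the structure. With the core of compound 1 held fixed, 3,4-dichlorophenyl in place of 4-aminophenyl gives a large step of a number 111 percentage points higher from compound 1 to compound 3 (beyond the scatter) and so shows that the effect at the concentration tested depends strongly on what sits at this position, something the earlier pair, which offered no comparison at a single place, could not reveal. Nothing at hand accounts for the size of this step.

One step cannot tell whether the change in the read-out follows from losing the 4-aminophenyl or from gaining the 3,4-dichlorophenyl, and it gives no sign of how the two chlorine atoms each contribute. Also open, from the compounds shown here alone, is where an unsubstituted phenyl, a 4-chlorophenyl or a 4-hydroxyphenyl on the same carbonyl carbon would fall, and whether the same exchange would give a step of similar size on a core carrying a different pattern of methoxy groups.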